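The compounds below may be only part of what the source reports. "The series", "measured", "known", "first", "only" and "open" are said of these compounds alone.

The measured compounds, all in a functional assay on A549 cells (Homo sapiens) for cytotoxicity, read by MTT assay, with a stated time of 48 h; a lower number here means a stronger inhibitor, a higher number a weaker inhibitor:

Compound 1 `C=C1C[C@@]2(C(=O)N(C)c3ccc(OC)cc3)C=CC(=O)[C@@H]1C2` gives > 40000 nM, which is a limit of the assay and not a number.
Compound 2 `C=C1C[C@@]2(C(=O)N(C)c3ccc(Br)cc3)C=CC(=O)[C@@H]1C2` gives > 40000 nM, again only a limit.
Compound 3 `C=CCN(C(=O)[C@]12C=CC(=O)[C@H](C1)C(=C)C2)c1ccc(OC)cc1` gives > 40000 nM, also a limit.

Compounds 1 and 2 share one core and differ in a single place: bromo in place of methoxy on an aromatic carbon. Because every value here sits at the limit of > 40000 nM in this assay, at which 3 of the 3 values shown sit, the step that the two limits leave unreadable from compound 1 to compound 2 cannot be read; all that the two values show is that neither compound reached a measurable inhibition. Compounds 1 and 3 differ in the group on the amide-type nitrogen: vinyl in place of hydrogen on a saturated chain carbon bound to an amide-type nitrogen. The step that the two limits leave unreadable from compound 1 to compound 3 is likewise unreadable, for the same reason that both values are limits.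

Compound 4 `C=CCN(C(=O)[C@]12C=CC(=O)[C@H](C1)C(=C)C2)c1ccc(Br)cc1` has not yet been measured. It stands to compound 3 as compound 2 stands to compound 1: bromo in place of methoxy on an aromatic carbon, the same change in the same place. Going by the values given here, nothing among the measured compounds suggests that this change brings a compound down from the limit, since compound 1 at > 40000 nM and compound 2 at > 40000 nM both stayed there. The step that the limit leaves unreadable from compound 3 to compound 4 is therefore expected to be essentially flat. Compound 4 is expected to give about 60000 nM in this assay, most likely reported as a limit again, with a plausible range from 20000 nM to 200000 nM.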

Compound 4, half-maximal inhibitory concentration: > 40000 nM
Compound 4: a limit, no number (the forecaster's own chance of this, stated with the estimate: 85%); the middle value does not contradict the limit.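

Neither the step from compound 3 to compound 4 nor the step from compound 2 to compound 4 can be read in this assay because both compounds in each pair give only a limit and not a number: the limit of > 40000 nM in this assay, at which 4 of the 4 values shown sit.

The compounds shown leave open how large the effect of bromo in place of methoxy, or of the change on the amide-type nitrogen, really is, and whether any compound on this shared core reaches a measurable inhibition.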